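The compounds below may be only part of what the source reports. "The series", "measured", "known", "first", "only" and "open" are said of these compounds alone.

Of the compounds shown here, three sharing one core have been measured in an assay on isolated protein for inhibition of Indoleamine 2,3-dioxygenase 1 (Homo sapiens), with a stated time of 60 min, tested at 10 uM; a lower number here means less inhibition, a higher number more inhibition at the concentration tested (going by the name of the read-out). Compound 1 `Clc1ccc2[nH]c(SCc3ccccc3Oc3ccccc3)nc2c1` gives 30% in this assay, compound 2 `Clc1ccc2[nH]c(SCc3ccccc3/C=C\c3ccccc3)nc2c1` gives 49%, and compound 3 `Clc1ccc2[nH]c(SCc3ccccc3CCCc3ccccc3)nc2c1` gives 19%. Compound 3 stands lowest of the three: the step of a number 11 percentage points lower from compound 1 to compound 3 (beyond the scatter) and the step of a number 30 percentage points lower from compound 2 to compound 3 (beyond the scatter) both lie beyond the scatter, while the step of a number 19 percentage points higher from compound 1 to compound 2 (beyond the scatter) separates the two higher compounds from each other.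

Compound 4 `[O-][S+](Cc1ccccc1)c1ccccc1CSc1nc2cc(Cl)ccc2[nH]1` has not yet been measured in this assay. It differs from compound 3 in one place: a group of 9 heavy atoms (7 carbon, 1 oxygen, 1 sulfur; one six-membered aromatic ring of carbon only) in place of a group of 9 heavy atoms (9 carbon; one six-membered aromatic ring of carbon only), on an aromatic carbon. Of the measured steps, the two that end at compound 3 bear on it most, since each replaced a different side group with the 3-phenylpropyl that now leaves again. Among the compounds with values here, the entering group, like the phenoxy of compound 1, holds an oxygen and a hydrogen-bond acceptor, whereas the 2-phenylethenyl of compound 2 holds neither; there is no measured pair with a group of this kind, so the expectation rests on reversing the loss seen in compound 3. A modest rise is therefore expected, with the step estimated as a number 11 percentage points higher from compound 3 to compound 4 (beyond the scatter). Compound 4 is expected to give about 30% in this assay, within a range from 10% to 55%.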

Compound 4, a percentage reported as inhibition, at one concentration (the size of the read-out at that concentration, not a potency): 11%
Estimate against measurement, compound 4: 19 percentage points above; the range from low to high includes it.
By their numbers in this assay, from the lowest: compounds 4 and 3 (each within the scatter of the next); then compound 1; then compound 2.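

In this assay, putting the group of oxygen, sulfur and carbon in place of the 3-phenylpropyl gives a number 8 percentage points lower from compound 3 to compound 4 (within the scatter), so this position does not separate these two groups of equal heavy-atom count, one with a hydrogen-bond acceptor and one without. The acceptor shared with the phenoxy of compound 1 does not bring the number to that compound's level, as the result of a number 19 percentage points lower from compound 1 to compound 4 (beyond the scatter) shows, so among the compounds shown, holding an acceptor does not go with a higher number. Within the data shown here, with a number 38 percentage points lower from compound 2 to compound 4 (beyond the scatter), the largest step so far, the 2-phenylethenyl stands further apart from the other groups at this position, and no measurement is available to explain any of these differences.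

The compounds shown leave open whether the oxygen on the sulfur matters at all, which a plain benzylthio group or a benzylsulfonyl group in the same place would test. They also leave open whether the number of compound 2 depends on its double bond, which a 2-phenylethyl group or the other geometric isomer of the 2-phenylethenyl would test.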